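The compounds below may be only part of what the source reports. "The series", "measured", "known", "first", "only" and "open" are said of these compounds alone.

Measured so far:
Compound 1, `COc1ccc(-c2cc(/C=C/C(=O)c3ccc(N)cc3)[nH]n2)cc1`: -63%
Compound 2, `COc1ccc(C(=O)/C=C/c2cc(-c3cc(OC)c(OC)c(OC)c3)n[nH]2)cc1`: -93%

Compound 1 was tested in a functional assay on RXF 393 cells (Homo sapiens) for cytotoxicity, read by sulforhodamine B assay, with a stated time of 48 h, tested at 100 uM (on this read-out higher numbers stand for a weaker effect at the one concentration tested and lower numbers for a stronger effect), and gives -63%. Of the two numbers shown, compound 1 holds the highest, and the nearest, compound 2 at -93%, lies lower by more than the usual scatter. Compound 3, `COc1ccc(-c2cc(/C=C/C(=O)c3ccc(N)cc3)[nH]n2)cc1OC`, is not yet measured in this assay. It differs from compound 1 by methoxy in place of hydrogen on an aromatic carbon. With no directly comparable step shown, the writer expects at most a modest step downward, perhaps not beyond the scatter, from compound 1 to compound 3 of a number 9 percentage points lower from compound 1 to compound 3 (within the scatter). For compound 3 the expected value in this assay is -72%, between -96% and -45%.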

Compound 3, a percentage reported as activity, at one concentration (the size of the read-out at that concentration, not a potency): -95%
Estimate against measurement, compound 3: 23 percentage points above; the measured number falls inside the stated range.
By their numbers in this assay, from the lowest: compounds 3 and 2 (each within the scatter of the next); then compound 1.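

In this assay, methoxy in place of hydrogen on an aromatic carbon, ortho to a methoxy group, gives a number 32 percentage points lower from compound 1 to compound 3 (beyond the scatter). This single-place change shows that this position of the core of compound 1 responds strongly to substitution, which the two earlier compounds could not show. Nothing measured here explains the step. The compounds shown leave open whether a hydroxyl, an ethoxy group or a fluorine at this same place would give a step of similar size. They also leave open whether the step depends on the methoxy group already present.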